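Benzyl in place of dichlorophenyl on a urea nitrogen

A few compounds are considered here, and "the series" means these few. Any claim that something is new, unique, unknown or untested is made for them only; others in the source may bear on it.

Compound 1 `COc1cc(OC)c2c(=O)cc(C(=O)Nc3cccc(N4CCCC4)c3)[nH]c2c1`: > 58600 nM
Compound 2 `COC(=O)c1cc(=O)c2cc(NC(=O)Nc3ccc(Cl)c(C(F)(F)F)c3)ccc2[nH]1`: > 6350 nM
Compound 3 `COC(=O)c1cc(=O)c2cc(NC(=O)Nc3ccc(Cl)c(Cl)c3)ccc2[nH]1`: > 6350 nM

Every value shown in a functional assay on HepG2 cells (Homo sapiens) for antiproliferative activity, with a stated time of 72 h (a higher number here means that more compound is needed for the effect, a lower number that less compound is needed), is a limit of the assay, not a number. Compound 1 sits at the limit of > 58600 nM in this assay, at which 1 of the 3 values shown sits. Compound 3, like compound 2, sits at the limit of > 6350 nM in this assay, at which 2 of the 3 values shown sit. Within the data shown here, since both ends are limits, a step that the two limits leave unreadable from compound 2 to compound 3 cannot be read, so no measured step gives a usable size.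

Compound 4 `COC(=O)c1cc(=O)c2cc(NC(=O)NCc3ccccc3)ccc2[nH]1` differs from compound 3 by benzyl in place of 3,4-dichlorophenyl on an amide-type nitrogen. With no readable step to lean on, compound 4 is expected to stay around the limit of compound 3, so the estimated step that the limit leaves unreadable from compound 3 to compound 4 is not beyond the scatter. Compound 4 is estimated at 10000 nM, within 3000 nM to 40000 nM.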

Compound 4, half-maximal effective concentration: > 19500 nM
Compound 4 gave a limit, no number (the forecaster's own chance of this, stated with the estimate: 70%); middle value at least 1.9-fold (0.29 log units) from the limit.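

Compound 4 gives > 19500 nM in this assay and this is a limit, not a number. Compound 3 gives > 6350 nM as a limit too, so the step from compound 3 to compound 4 cannot be read. How strongly any of these compounds acts in this assay stays open, as does whether benzyl or 3,4-dichlorophenyl needs less compound.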